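Thiophene in place of carboxyphenyl on a shared core

The source may report more compounds than this note shows. Statements on the series, on what has been measured and on what is new or still open speak of the compounds shown alone.

Compound 1 `Cc1ccccc1-n1nc(C)c2c1NC(=O)[C@H](C)S[C@@H]2c1ccc(-c2cccc(C(=O)O)c2)cc1`: "not active" (no number reported)
Compound 2 `COc1ccc(C2SC(C)C(=O)Nc3c2c(C)nn3-c2ccccc2C)c(OC)c1`: 10500 nM
Compound 3 `Cc1nn(-c2ccccc2Cl)c2c1C(c1ccc(Oc3ccccc3)cc1)SC(C)C(=O)N2`: 2700 nM

Of the compounds shown here, three on the shared core have been tested in an assay on isolated protein for agonist activity at Bile acid receptor (Homo sapiens), read by AlphaScreen, with a stated time of 30 min; on this read-out lower numbers stand for an effect already at smaller amounts and higher numbers for an effect only at larger amounts of compound. Compound 1 is reported as "not active" (no number reported), with no number attached, so it stands nowhere on the scale of the others. Compound 2 gives 10500 nM in this assay. Compound 3 gives 2700 nM in this assay. No pair among these three differs in a single place, so no step can be read off.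

Compound 4 `Cc1ccccc1-n1nc(C)c2c1NC(=O)[C@H](C)S[C@@H]2c1ccc(-c2ccsc2)cc1` is the new compound, and it differs from compound 1 as follows: thiophen-3-yl in place of 3-carboxyphenyl on an aromatic carbon. Since compound 1 has no number, the step from compound 1 to compound 4 cannot be sized; the direction expected in this assay is toward a measurable number, and the scatter of repeated measurements gives the width of that expectation.

For compound 4 an effect is estimated in this assay at around 5000 nM, expected between 1500 nM and 20000 nM, with a real chance that no number is reported at all.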

Compound 4, half-maximal effective concentration: 1400 nM
The estimate for compound 4 lay 3.6-fold (0.55 log units) above the measured number; measured number outside the range, below it.
By their numbers in this assay, from the lowest: compounds 4 and 3 (each within the scatter of the next); then compound 2.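

In this assay, for the compounds shown here, compound 4 gives 1400 nM, while compound 1 carries no number, so no step between compound 1 and compound 4 can be read. The compounds shown leave open what thiophen-3-yl in place of 3-carboxyphenyl changes in size. No measurement here offers an explanation for the result.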